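Compound 2 to compound 3: methyl to hydrogen

This account rests on a few compounds, and the source may have more. Where it says the series, first, only, none or still open, it means among the compounds named here.

In a functional assay on MDA-MB-231 cells (Homo sapiens) for antiproliferative activity, with a stated time of 5 days (on this read-out lower numbers stand for stronger inhibition and higher numbers for weaker inhibition), compound 2 `Cc1ccccc1-n1nc(-c2cccc3ccccc23)nc1N1C(=O)COC12C=CC(=O)C=C2` gives 120 nM. Within the data shown here, the only other measured member of the series is compound 1 `CC1CN(c2nc(-c3ccc4ccccc4c3)nn2-c2ccccc2)C2(C=CC(=O)C=C2)O1`, which gives 130 nM in this assay. Compound 2 has the lower of the two numbers, but the two values lie within the scatter of each other.

Compound 3 `O=C1C=CC2(C=C1)OCC(=O)N2c1nc(-c2cccc3ccccc23)nn1-c1ccccc1` differs from compound 2 in one place: hydrogen in place of methyl on an aromatic carbon. This is hydrogen in place of methyl on an aromatic carbon, ortho to a large group, so 2-methylphenyl becomes phenyl. Among the measured compounds shown here, no measured pair shows this change, so its size in this assay is not known. The expectation rests on compound 2 at 120 nM, with no shift beyond the scatter in either direction.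

The expected change is a 1.1-fold higher number from compound 2 to compound 3 (0.03 log units; within the scatter). For compound 3 the estimated value is 130 nM, with an expected range of 50 nM to 330 nM.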

Compound 3, half-maximal inhibitory concentration: 50 nM
Compound 3: the middle estimate sits 2.6-fold (0.41 log units) above what was measured; the measured number falls inside the stated range.
By their numbers in this assay, from the lowest: compound 3; then compounds 2 and 1 (each within the scatter of the next).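

In this assay, the position on the aromatic carbon ortho to a large group turns out to matter: a 2.4-fold lower number from compound 2 to compound 3 (0.38 log units; beyond the scatter), a modest step but beyond the scatter, so 2-methylphenyl to phenyl is not a silent change here. Among these compounds, this is the first single-place pair, and within it the phenyl compound carries the lower number, though that reading rests on this one pair alone. Nothing at hand accounts for the size or direction of the step.

Still open, as far as these compounds go, is whether a fluorine, a chlorine or a methoxy group at this place would read closer to compound 2 or to compound 3. Also open, from the compounds shown here alone, is whether the same change gives a similar step when the rest of the structure differs, as it does in compound 1.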